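Pyridyl variation at the sulfonamide nitrogen of the series

A few compounds are considered here, and "the series" means these few. Any claim that something is new, unique, unknown or untested is made for them only; others in the source may bear on it.

Measured so far:
compound 1, `CCc1ccccc1N(CC(=O)NCc1ccc(C(F)(F)F)cc1)S(=O)(=O)c1ccc(C)cc1`: 209 nM
compound 2, `Cc1ccc(S(=O)(=O)N(CC(=O)NCc2ccc(Cl)cc2)c2ccccn2)cc1`: < 1450 nM

Both compounds share a tolyl sulfonamide carrying a glycinamide linked to a benzylamine, and differ in the group on the sulfonamide nitrogen and in the substituent on the benzylic ring. In a functional assay on CHO-K1 cells for antagonist activity at prostaglandin E2 receptor EP1 subtype (Homo sapiens), read by FLIPR and calcium flux (on this read-out lower numbers stand for stronger inhibition and higher numbers for weaker inhibition), compound 1 gives 209 nM. For compound 2 the value of < 1450 nM is a limit of the assay, not a number. Compound 2 stands at the limit of < 1450 nM in this assay, at which 1 of the 2 values shown sits, so where it lies beneath that limit is not known.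

Compound 3, `Cc1ccc(S(=O)(=O)N(CC(=O)NCc2ccc(Cl)cc2)c2ccc(C)nc2)cc1`, is not yet measured. It differs from compound 2 in one place: 6-methylpyridin-3-yl in place of pyridin-2-yl on a sulfonamide nitrogen. Among the compounds with values here, with only a limit for compound 2, no measured step frames this change, and its size and direction cannot be taken from the series so far. The estimate for compound 3 in this assay is 800 nM, with a range from 150 nM to 4000 nM, which corresponds to an expected step that the limit leaves unreadable from compound 2 to compound 3.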

Compound 3, inhibition constant: < 1450 nM
Compound 3: no number, only a limit (the forecaster's own chance of this, stated with the estimate: 35%); the middle value lies beyond the limit too.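

In this assay compound 3 gives < 1450 nM, a limit of the assay and not a number. Compound 2 also stands at a limit, so no step between compound 2 and compound 3 can be read: the limit of < 1450 nM in this assay, at which 2 of the 3 values shown sit.

Where each compound lies relative to that limit stays open, and with it the size and direction of the change from pyridin-2-yl to 6-methylpyridin-3-yl.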